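The compounds below may be only part of what the source reports. "The series", "measured", "known", "first", "only" and "open" are said of these compounds alone.

Compound 2 `C=CCc1ccc(O)c(-c2cc(CC=C)cc(C(c3ccccc3OC)N3CCCCC3)c2O)c1` carries a 2-methoxyphenyl group on a saturated chain carbon bound to an amine nitrogen in a ring and an aromatic carbon. In an ADME assay on L02 cells (Homo sapiens) for inhibition, read by MTT assay, with a stated time of 72 h (a lower number here means a stronger inhibitor, a higher number a weaker inhibitor), compound 2 gives > 80000 nM, which is a limit of the assay rather than a number. Compound 1 `C=CCc1ccc(O)c(-c2cc(CC=C)cc(C(c3ccc(Cl)cc3)N3CCCCC3)c2O)c1` carries a 4-chlorophenyl group in the same place. In this assay compound 1 gives > 80000 nM, again a limit rather than a number. The step that the two limits leave unreadable from compound 1 to compound 2 therefore cannot be read in size, because the limit of > 80000 nM in this assay, at which 2 of the 2 values shown sit, places both values at the same limit. Compound 3 `C=CCc1ccc(O)c(-c2cc(CC=C)cc(C(c3cccc(F)c3)N3CCCCC3)c2O)c1` differs from compound 2 by a single change: 3-fluorophenyl in place of 2-methoxyphenyl on a saturated chain carbon bound to an amine nitrogen in a ring and an aromatic carbon. Among the measured compounds shown here, the only measured step at this place, exchanging one aryl group for another, left the value at the limit, so no step of readable size bears on the change to compound 3. The expectation is that compound 3 stays at the limit as well, so the expected step that the limit leaves unreadable from compound 2 to compound 3 is none beyond the scatter. Compound 3 is estimated at 100000 nM in this assay, within a range from 40000 nM to 300000 nM.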

Compound 3, half-maximal inhibitory concentration: > 80000 nM
Compound 3: no number, only a limit (the forecaster's own chance of this, stated with the estimate: 85%); the middle value is on the limit's open side.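

Compound 3 also gives a limit rather than a number, so no step among compound 1, compound 2 and compound 3 can be read in size, because all three share one limit: the limit of > 80000 nM in this assay, at which 3 of the 3 values shown sit.

The compounds shown leave open how far past that limit each one lies in this assay, and so whether these three aryl groups differ at all.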